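From Methylsulfonyl Piperazine to a Simple Amino Group

The compounds below may be only part of what the source reports. "The series", "measured", "known", "first", "only" and "open" are said of these compounds alone.

Measured in a functional assay on NCI-H1581 cells (Homo sapiens) for antiproliferative activity, read by CCK-8 assay, with a stated time of 72 h; on this read-out higher numbers stand for weaker inhibition and lower numbers for stronger inhibition:
- compound 1 `COc1cc(OC)c(Cl)c(-c2ccc3c(NC(=O)c4ccc(N5CCN(C6CCC6)CC5)cc4)n[nH]c3n2)c1Cl`: 2.3 nM
- compound 2 `COc1cc(OC)c(Cl)c(-c2ccc3c(NC(=O)c4ccc(N5CCN(S(C)(=O)=O)CC5)cc4)n[nH]c3n2)c1Cl`: 245 nM

Compound 2, at 245 nM, holds the higher of the two numbers, so it is the weaker inhibitor of this pair. The next compound, compound 3 `COc1cc(OC)c(Cl)c(-c2ccc3c(NC(=O)c4ccc(N)cc4)n[nH]c3n2)c1Cl`, has amino in place of 4-(methylsulfonyl)piperazin-1-yl on an aromatic carbon of a six-membered aromatic ring of carbon only, para to a large group: amino in place of 4-(methylsulfonyl)piperazin-1-yl on an aromatic carbon.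

Among the measured compounds shown here, only one measured step bears on this change. It is a 110-fold higher number from compound 1 to compound 2 (2.03 log units; beyond the scatter), with methylsulfonyl in place of cyclobutyl on an amine nitrogen in a ring. That large step shows that the group on this ring can move the number a long way. Both measured compounds keep the ring, however, so no measurement shows what happens when it is removed entirely. A result in either direction remains possible, and the range must be wide.

The estimated step is a 2.5-fold lower number from compound 2 to compound 3 (0.39 log units; beyond the scatter), a modest move towards stronger inhibition in this assay. For compound 3 the expected value is 100 nM, with an estimated range of 15 nM to 600 nM.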

Compound 3, half-maximal inhibitory concentration: 218 nM
Compound 3: middle estimate off by 2.2-fold (0.34 log units), on the low side; low and high end bracket the measured number.
By their numbers in this assay, from the lowest: compound 1; then compounds 3 and 2 (each within the scatter of the next).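

In this assay, replacing the whole 4-(methylsulfonyl)piperazin-1-yl group with amino gives a 1.1-fold lower number from compound 2 to compound 3 (0.05 log units; within the scatter), so this large group, with its 10 heavy atoms and its ring, can give way to a single nitrogen with no change beyond the scatter. Set against the cyclobutyl partner, the same amino replacement gives a 95-fold higher number from compound 1 to compound 3 (1.98 log units; beyond the scatter), which shows that among these three compounds the low number belongs only to the piperazine carrying cyclobutyl, and that the ring with methylsulfonyl on it offers no measurable gain over having no ring at all. Nothing available here explains why these groups give these numbers.

The compounds shown leave open how much of the effect depends on cyclobutyl itself, since a piperazine with only a hydrogen, a methyl group or an open butyl chain on that nitrogen would help separate the role of the ring from that of its substituent. As far as these compounds go, it also remains open whether another ring, such as a morpholine, could take the place of the piperazine in this position.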